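This account rests on a few compounds, and the source may have more. Where it says the series, first, only, none or still open, it means among the compounds named here.

Measured compounds in an assay on isolated protein for inhibition of DNA topoisomerase 1 (Homo sapiens), with a stated time of 30 min, tested at 100 uM; on this read-out higher numbers stand for more inhibition at the one concentration tested (going by the name of the read-out) and lower numbers for less inhibition:
Compound 1 `Clc1cccc(-c2cc(-c3ccoc3)cc(-c3ccc(Cl)s3)n2)c1` gives 2.1%.
Compound 2 `Clc1ccc(-c2cc(-c3ccoc3)cc(-c3ccc(Cl)s3)n2)cc1` gives 2.3%.

Among the compounds with values here, both numbers are small, meaning that at the single concentration tested neither compound inhibits the enzyme to any notable degree. Compound 2 stands alongside compound 1 rather than apart from it: the step of a number 0.2 percentage points higher from compound 1 to compound 2 (within the scatter) lies within the usual scatter, so the two numbers cannot be told apart and neither number can be called the higher.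

Compound 3 `Clc1ccc(-c2cc(-c3ccoc3)cc(-c3cccnc3)n2)s1` has not been measured. Its difference from compound 2 is pyridin-3-yl in place of 4-chlorophenyl on an aromatic carbon. Within the data shown here, the only measured step, which swaps one chlorophenyl for another and leaves the rest of the shared core untouched, moved the read-out by an amount within the scatter. No measured step exchanges a chlorophenyl for a pyridinyl, so there is nothing to suggest that this change would lift the read-out far above the low level shown by compound 1 and compound 2.

The expectation for compound 3 is therefore a step of about a number 0.7 percentage points higher from compound 2 to compound 3 (within the scatter), which is no change beyond the scatter. Compound 3 is estimated at 3%, in the range -5% to 15%.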

Compound 3, a percentage reported as inhibition, at one concentration (the size of the read-out at that concentration, not a potency): 2%
Estimate against measurement, compound 3: 1 percentage points above; the measured number falls inside the stated range.
By their numbers in this assay, from the lowest: compounds 3, 1 and 2 (each within the scatter of the next).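

In this assay, the earlier pair only showed a chlorine moving around a benzene ring, whereas this change puts a different ring at the position next to the ring nitrogen: pyridin-3-yl brings a ring nitrogen and carries no chlorine. The read-out does not register this larger swap, with a step of a number 0.3 percentage points lower from compound 2 to compound 3 (within the scatter) and, against the other chlorinated compound, a step of a number 0.1 percentage points lower from compound 1 to compound 3 (within the scatter). So for these three compounds, neither the chlorine nor the all-carbon ring separates one compound from another at this position, and nothing measured here explains why the three numbers stay together.

The compounds shown leave open whether a group of another kind at this position, such as an amine, a carboxylic acid or a longer chain ending in an amide, would carry the number beyond the scatter. They also leave open what the furan-3-yl and 5-chlorothiophen-2-yl groups contribute: both stay in place throughout, and swapping either for a plain phenyl or a methyl group would be the direct test.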